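Swapping the aryl group on a spirocyclic diaminotriazine scaffold

This account rests on a few compounds, and the source may have more. Where it says the series, first, only, none or still open, it means among the compounds named here.

Measured compounds:
compound 1, `NC1=NC2(CCOCC2)N(OCCCOc2ccc(Cl)c(Cl)c2)C(N)=N1`, 1240 nM
compound 2, `NC1=NC2(CCSCC2)N(OCCCOc2ccc(Br)cc2)C(N)=N1`, 350 nM
compound 3, `NC1=NC2(CCSCC2)N(OCCCOc2cc(Cl)c(Cl)cc2Cl)C(N)=N1`, 730 nM

In a functional assay on HL-60 cells (Homo sapiens) for antiproliferative activity, read by MTT assay, with a stated time of 72 h (a higher number here means a weaker inhibitor, a lower number a stronger inhibitor), compound 1 gives 1240 nM, the highest of the three numbers; compound 3 lies nearest to it, within the scatter, while compound 2 sits furthest away, beyond the scatter. Compound 4, `Cc1cc(C)cc(OCCCON2C(N)=NC(N)=NC23CCOCC3)c1`, has not yet been measured. It differs from compound 1 in one place: 3,5-dimethylphenyl in place of 3,4-dichlorophenyl on an oxygen on a saturated carbon. For the measured compounds named here, the only measured step that touches the aryl group is the one from compound 2 to compound 3, where the number rose a 2.1-fold higher number from compound 2 to compound 3 (0.32 log units; beyond the scatter), a modest shift on a related but not identical core. Going by the values given here, no measured pair shows a dichlorophenyl set against a dimethylphenyl, so the direction for compound 4 is uncertain. Given the modest size of the step between compound 2 and compound 3, compound 4 is expected to land near compound 1, with a step of a 1.2-fold higher number from compound 1 to compound 4 (0.08 log units; within the scatter). Compound 4 is therefore estimated at 1500 nM, within a range from 600 nM to 4000 nM.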

Compound 4, half-maximal inhibitory concentration: 720 nM
The estimate for compound 4 lay 2.1-fold (0.32 log units) above the measured number, and the stated range covers the measured number.
By their numbers in this assay, from the lowest: compound 2; then compounds 4, 3 and 1 (each within the scatter of the next).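

In this assay, exchanging 3,4-dichlorophenyl for 3,5-dimethylphenyl on the core of compound 1 gives a 1.7-fold lower number from compound 1 to compound 4 (0.24 log units; within the scatter). This is the first aryl change shown on this core, and it shows that, for this pair, an aryl group bearing only carbon reads the same within the scatter as the chlorine-bearing one, so the chlorine atoms are not needed to keep the number in this range. No further data bear on why the two compounds read alike.

Because the change replaces both the substituents and their placement on the ring, this single pair cannot separate the two, and 3,5-dichlorophenyl on the same core would be needed to do so. From the compounds shown here alone, how a pyridine ring, an aryl amine or a carboxylic acid would read at this place also remains open, as does a longer chain linking the aryl group.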